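The source may hold more compounds than are shown below. What is called first, only, known or untested is meant among the compounds shown, and "the series" means these compounds.

Measured so far in an ADME assay on microsomes from liver (Homo sapiens) for metabolic stability, with a stated time of 10 min; on this read-out lower numbers stand for a less stable compound and higher numbers for a more stable compound:
- Compound 1 `CC[C@]1(C(=O)O)CC[C@H](C(=O)N2CC[C@](c3ccc(C(F)(C(F)(F)F)C(F)(F)F)cc3)(S(=O)(=O)c3ccc(F)cc3)C2)CC1`: 100%
- Compound 2 `O=C(O)[C@H]1CC[C@](F)(C(=O)N2CC[C@](c3ccc(C(F)(C(F)(F)F)C(F)(F)F)cc3)(S(=O)(=O)c3ccc(F)cc3)C2)CC1`: "not determined" (no result reported)

Going by these compounds, compound 2 offers no number to work from, since its entry reads "not determined" (no result reported), so its place on this scale is unknown. Compound 3 `O=C([C@H]1CC[C@H](c2nnn[nH]2)CC1)N1CC[C@](c2ccc(C(F)(C(F)(F)F)C(F)(F)F)cc2)(S(=O)(=O)c2ccc(F)cc2)C1` is still to be measured. The structural step 4-(1H-tetrazol-5-yl)cyclohexyl in place of 4-carboxy-1-fluorocyclohexyl on a carbonyl carbon puts 4-(1H-tetrazol-5-yl)cyclohexyl in place of 4-carboxy-1-fluorocyclohexyl on a carbonyl carbon. The rest of the molecule stays the same.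

For the measured compounds named here, no measured pair shows what a swap like this does in this assay, so any forecast rests on thin evidence. Going by the values given here, the only available guide is compound 1, which shares the core and gives 100%. Compound 3 is therefore expected to stay near that level, with a step no larger than the usual scatter. Any shift is expected to be towards a less stable compound because compound 1 at 100% leaves little room higher up.

For compound 3 the estimated value is 92%, with an expected range from 75% to 100%.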

Compound 3, percent of the compound remaining: 100%
Compound 3: the middle estimate sits 8 percentage points below what was measured, within the range that was stated.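

In this assay, for the compounds shown here, replacing 4-carboxy-4-ethylcyclohexyl with 4-(1H-tetrazol-5-yl)cyclohexyl on the carbonyl carbon gives no change at the digits printed from compound 1 to compound 3 (within the scatter) as the first readable step at this position. So this place on the shared core can carry either a cyclohexyl ring with a carboxylic acid and an ethyl group or one with a tetrazole, with no loss visible on this read-out, although compound 1 and compound 3 both sit at the top of the scale, which leaves no room to tell whether either would outlast the other in a harder test. Nothing measured here explains why the read-out holds steady.

Going by these compounds, compound 2 has no number, so the steps to it cannot be read, and the effect of its 4-carboxy-1-fluorocyclohexyl group stays unknown. Also open, on these data alone, is whether a cyclohexyl ring carrying an amine or a primary amide in place of the carboxylic acid or tetrazole would give the same result at this position.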